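The compounds below may be only part of what the source reports. "The series", "measured", "known", "first", "only" and "open" are said of these compounds alone.

Measured compounds in the series:
- compound 1, `CC#CCN(C)Cc1cc2cc(O)ccc2n1C`: 5.7 nM
- compound 2, `C#CCN(C)Cc1cn(Cc2ccccc2)c2ccccc12`: 160000 nM
- compound 3, `C#CCN(Cc1ccccc1)Cc1cc2ccccc2n1C`: 10000 nM

In an assay on isolated protein for inhibition of Amine oxidase [flavin-containing] A (Rattus norvegicus) (a higher number here means a weaker inhibitor, a lower number a stronger inhibitor), compound 1 gives the lowest number of the three, far apart from both others. Compound 3 gives 10000 nM and compound 2 gives 160000 nM in this assay; each differs from compound 1 in several places at once, so the two weak values say nothing on their own about any single change.

Compound 4, `C#CCN(C)Cc1cc2cc(O)ccc2n1C`, is not yet measured. It differs from compound 1 by hydrogen in place of methyl on a triple-bonded carbon. Among the compounds with values here, no pair of measured compounds differs by this change alone, so its size is unknown from the data. Because compound 1 gives 5.7 nM and the change is confined to the terminus of the alkyne, the step is expected to be small, in either direction, and possibly within the usual scatter. The estimate for compound 4 is 10 nM, with a range from 1.5 nM to 70 nM; this means an expected step of a 1.8-fold higher number from compound 1 to compound 4 (0.24 log units; within the scatter).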

Compound 4, inhibition constant: 4 nM
Estimate against measurement, compound 4: 2.5-fold (0.40 log units) above; low and high end bracket the measured number.
By their numbers in this assay, from the lowest: compounds 4 and 1 (each within the scatter of the next); then compound 3; then compound 2.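

In this assay the alkyne terminus now has its first single-change reading: a 1.4-fold lower number from compound 1 to compound 4 (0.15 log units; within the scatter) is a step within the scatter, so methyl and hydrogen on this triple-bonded carbon cannot be told apart on the core of compound 1. Going from but-2-yn-1-yl to propargyl therefore leaves the number low, and this position accepts either end group without a readable change. Nothing measured in this part of the series speaks to the reason for this result.

Still open, on these data alone, is whether a longer chain on the triple-bonded carbon, such as an ethyl or propyl group, or a larger phenyl group would also keep the number low. As far as these compounds go, the contribution of the hydroxyl group on the shared core also remains open, including whether a methoxy group or an amine could stand in its place.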